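The compounds below may be only part of what the source reports. "The series", "measured", "known", "first", "only" and "open" are said of these compounds alone.

Compound 1 `CCOC(=O)C1=Cc2ccccc2OC1(OCc1cn(CC(=O)Nc2ccccc2Br)nn1)C(F)(F)F` is tested in a functional assay on HeLa cells (Homo sapiens) for inhibition, read by MTT assay, with a stated time of 24 h; on this read-out lower numbers stand for stronger inhibition and higher numbers for weaker inhibition. In this assay compound 1 gives > 150000 nM, which is a limit of the assay rather than a number. Two other compounds share its core. Compound 2 `CCOC(=O)C1=Cc2ccccc2OC1(OCc1cc(-c2cccc(C(F)(F)F)c2)no1)C(F)(F)F` gives 21400 nM in this assay, and compound 3 `CCOC(=O)C1=Cc2ccccc2OC1(OCc1cc(-c2ccc(Cl)cc2)no1)C(F)(F)F` gives 12300 nM. Among the compounds with values here, the only measured step between them, a 1.7-fold lower number from compound 2 to compound 3 (0.24 log units; within the scatter), concerns a different ring and so does not bear on the change from compound 1. Compound 4 `CCOC(=O)C1=Cc2ccccc2OC1(OCc1cn(-c2ccc([N+](=O)[O-])cc2)nn1)C(F)(F)F` differs from compound 1 by 4-nitrophenyl in place of ((2-bromophenyl)carbamoyl)methyl on an aromatic nitrogen. Within the data shown here, no measured step shows how this change acts, and compound 1 itself sets only a limit (the limit of > 150000 nM in this assay, at which 1 of the 3 values shown sits). Compound 4 is therefore expected to remain weak, with an expected step of an at least 1.5-fold lower number from compound 1 to compound 4 (0.17 log units; that floor lies within the scatter). The estimate for compound 4 is 100000 nM, between 20000 nM and 300000 nM.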

Compound 4, half-maximal inhibitory concentration: > 150000 nM
Compound 4: a limit, no number; the forecaster's own chance of this, stated with the estimate: 55%; at least 1.5-fold (0.17 log units) between middle value and limit.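

Compound 1 and compound 4 both give a limit rather than a number in this assay, so no step between them can be read: the limit of > 150000 nM in this assay, at which 2 of the 4 values shown sit.

The compounds shown leave open what 4-nitrophenyl in place of ((2-bromophenyl)carbamoyl)methyl on the aromatic nitrogen actually does to inhibition.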